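A few compounds are considered here, and "the series" means these few. Any claim that something is new, unique, unknown or untested is made for them only; others in the source may bear on it.

Measured so far in a functional assay (strain AB) with Danio rerio as the target, read by microscopy, with a stated time of 1 h; on this read-out higher numbers stand for an effect only at larger amounts of compound and lower numbers for an effect already at smaller amounts:

Compound 1 `CC(C)(C)OC(=O)CCCC[N+]1(C)CCc2c(sc(NC(=O)Nc3ccc(Cl)cc3)c2C(N)=O)C1` gives 140 nM.
Compound 2 `CCN1CCc2c(sc(NC=O)c2C(N)=O)C1` gives only a limit of the assay, > 25000 nM.
Compound 3 `CCN1CCc2sc(NC(=O)Nc3ccc(Cl)cc3)c(C(N)=O)c2CC1` gives 5800 nM.

Among these results compound 1 stands lowest, and the nearest measured neighbour is compound 3, whose number lies far above it, well beyond the usual scatter of repeated runs. Compound 2 contributes no number, only (the limit of > 25000 nM in this assay, at which 1 of the 3 values shown sits). Among the compounds with values here, no two of the three measured compounds differ in a single place, so no measured step of known size exists to lean on.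

Compound 4 `C[N+]1(CC2CCCC2)CCc2c(sc(NC(=O)Nc3ccc(Cl)cc3)c2C(N)=O)C1` has not yet been tested in this assay. It differs from compound 1 in one spot: cyclopentyl in place of 3-(tert-butoxycarbonyl)propyl on a saturated chain carbon bound to an amine nitrogen in a ring. Everything else in compound 1 is kept, including the charged ring nitrogen with its methyl.

No comparable exchange has been measured here, so the size of the step is uncertain. The expected step of a 2.1-fold higher number from compound 1 to compound 4 (0.33 log units; beyond the scatter) is modest, toward a somewhat higher number, and may not clearly exceed the scatter. Compound 4 is therefore expected to give about 300 nM, with a likely span from 80 nM to 1500 nM.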

Compound 4, half-maximal effective concentration: 200 nM
Compound 4: the middle estimate sits 1.5-fold (0.18 log units) above what was measured; the measured number falls inside the stated range.
By their numbers in this assay, from the lowest: compounds 1 and 4 (each within the scatter of the next); then compound 3. At a limit, above all of these: compound 2.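

In this assay, within the data shown here, the exchange of 3-(tert-butoxycarbonyl)propyl for cyclopentyl gives the first measured step between two compounds that differ in one place, a 1.4-fold higher number from compound 1 to compound 4 (0.15 log units; within the scatter), so this read-out does not separate the two compounds. On a saturated chain carbon bound to an amine nitrogen in a ring, a group of 10 heavy atoms with 2 hydrogen-bond acceptors gives way to a carbon-only ring of 5 heavy atoms with no acceptors, which shows that neither the open chain nor its tert-butoxycarbonyl end is needed for an effect at this level. Nothing available explains why these two different groups read alike.

As far as these compounds go, it remains open whether an amine, a carboxylic acid or a plain butyl chain at this place would also read like compound 1 and compound 4. Both of these compounds keep the methyl on the charged ring nitrogen, so no single exchange here shows what that methyl or the charge contributes.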